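The source may report more compounds than this note shows. Statements on the series, on what has been measured and on what is new or still open speak of the compounds shown alone.

Two compounds share one core. Compound 1 `CN(C)c1nccc2c1ncn2C1O[C@H](CO)[C@@H](O)[C@H]1O` gives 10% in a functional assay on EL4 cells (Mus musculus) for inhibition, tested at 100 uM (on this read-out lower numbers stand for less inhibition and higher numbers for more inhibition at the one concentration tested (going by the name of the read-out)), and compound 2 `OCCNc1nccc2c1ncn2C1O[C@H](CO)[C@@H](O)[C@H]1O` gives 6% in this assay; the step of a number 4 percentage points lower from compound 1 to compound 2 (within the scatter) lies within the scatter. Compound 2 therefore stands at the lower end of the two numbers, a gap within the scatter. Compound 3 `OC[C@H]1OC(n2cnc3c(S)nccc32)[C@H](O)[C@@H]1O` differs from compound 2 by sulfanyl in place of (2-hydroxyethyl)amino on an aromatic carbon. Among the measured compounds shown here, no measured step trades an amino group for sulfanyl, and the only step seen, a number 4 percentage points lower from compound 1 to compound 2 (within the scatter), stayed within the scatter. Compound 3 is therefore expected near 8%, between 0% and 20%. The expected step is a number 2 percentage points higher from compound 2 to compound 3 (within the scatter).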

Compound 3, a percentage reported as inhibition, at one concentration (the size of the read-out at that concentration, not a potency): < 5%
Compound 3 ended at the assay's limit; the forecaster's own chance of this, stated with the estimate: 5%; middle value at least 3 percentage points from the limit.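

In this assay compound 3 gives < 5%, a limit of the assay and not a number: the limit of < 5% in this assay, at which 1 of the 3 values shown sits.

The steps read a number at least 1 percentage points lower from compound 2 to compound 3 (that floor lies within the scatter) and a number at least 5 percentage points lower from compound 1 to compound 3 (that floor lies within the scatter). Among the compounds shown here, at this aromatic carbon next to the ring nitrogen, then, sulfanyl, the first group here without an amino nitrogen, gives no reading that stands apart from either amino compound.

As far as these compounds go, whether any group at this position can give inhibition clearly beyond these low readings stays open. A carboxylic acid, a methoxy group or a longer chain ending in an amine would address that question.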